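The source may hold more compounds than are shown below. What is called first, only, known or untested is meant among the compounds shown, and "the series" means these compounds.

Measured so far in an ADME assay on HEK293 cells (Homo sapiens) for cytotoxicity, with a stated time of 72 h; on this read-out lower numbers stand for an effect already at smaller amounts and higher numbers for an effect only at larger amounts of compound (both entries are limits):
- compound 1 `Cc1ccc(-c2nc3ccccc3s2)cc1NC(=O)c1cc([N+](=O)[O-])c(N(C)C)cc1Cl` gives > 25000 nM (limit)
- compound 2 `O=C(Nc1ccc(-c2nc3ccccc3s2)cc1)c1cc([N+](=O)[O-])ccc1Cl` gives > 27000 nM (limit)

Compound 2 stands at > 27000 nM as a limit of the assay, not a number. Compound 3 `O=C(Nc1ccc(-c2ccccc2)cc1)c1cc([N+](=O)[O-])ccc1Cl` has phenyl in place of 1,3-benzothiazol-2-yl on an aromatic carbon, para to a large group (phenyl in place of 1,3-benzothiazol-2-yl on an aromatic carbon). For the measured compounds named here, no measured step gives the size of this change. The expected change in this assay is a step that the limit leaves unreadable from compound 2 to compound 3 and is estimated as no step beyond the scatter, in neither direction. For compound 3 the estimated value is 30000 nM with an expected range from 12000 nM to 60000 nM and a report as a limit is likely.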

Compound 3, half-maximal effective concentration: > 27000 nM
Compound 3 was reported as a limit; the forecaster's own chance of this, stated with the estimate: 75%; the middle value is on the limit's open side.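

For the compounds shown here, compound 2 and compound 3 are both reported as limits in this assay, and no step between them can be read. The compounds shown leave open whether phenyl in place of 1,3-benzothiazol-2-yl changes this read-out at all, and at what concentration any of them reaches a half-maximal effect.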